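Swapping an amine on a benzophenone-bearing core

A few compounds are considered here, and "the series" means these few. Any claim that something is new, unique, unknown or untested is made for them only; others in the source may bear on it.

Three compounds share a core that carries a chlorinated benzophenone unit and a small basic side chain. Compound 1 `Cc1nnc(CN(C)C)n1-c1ccc(Cl)cc1C(=O)c1ccccc1` is joined by compound 2 `CN(C)Cc1nccn1-c1ccc(Cl)cc1C(=O)c1ccccc1Cl` and compound 3 `Cc1nc(CN(C)C)n(-c2ccc(Cl)cc2C(=O)c2ccccc2Cl)c1CO`. In a functional assay on the whole organism (strain CF-1) for inhibition, with Mus musculus as the target (a higher number here means that more compound is needed for the effect, a lower number that less compound is needed), compound 1 gives 1.1 mg/kg, compound 2 gives 1.8 mg/kg and compound 3 gives 1.8 mg/kg; both neighbours sit within the usual scatter of compound 1, so the three cannot be told apart on these numbers. Compound 4 `Cc1nnc(CN2CCCC2)n1-c1ccc(Cl)cc1C(=O)c1ccccc1` has not been measured. It differs from compound 1 in one place: pyrrolidin-1-yl in place of dimethylamino on a saturated chain carbon bound to an aromatic carbon. For the measured compounds named here, no measured pair shows such a change, so the step is expected to be small and not beyond the scatter, in either direction. Compound 4 is estimated at 1.3 mg/kg, ranging from 0.5 mg/kg to 3.5 mg/kg, a step of a 1.2-fold higher number from compound 1 to compound 4 (0.07 log units; within the scatter).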

Compound 4, dose for half-maximal effect: 2 mg/kg
For compound 4 the middle estimate is 1.5-fold (0.19 log units) below the measured one; measured number inside the range.
By their numbers in this assay, from the lowest: compounds 1, 2, 3 and 4 (each within the scatter of the next).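

In this assay, for the compounds shown here, this is the first measured pair that differs only at the amine on the saturated chain carbon bound to an aromatic carbon. Pyrrolidin-1-yl in place of dimethylamino gives a 1.8-fold higher number from compound 1 to compound 4 (0.26 log units; within the scatter), so the two compounds cannot be told apart, and this position accepts a ring amine here without a step beyond the scatter. Nothing measured here explains this result. Still open, on these data alone, is whether a six-membered ring amine such as piperidin-1-yl or morpholin-4-yl would read the same way. As far as these compounds go, a primary amine at this position is equally open.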